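Swapping a Methylbenzyl for a Cyanobenzyl on the Triazole

The source may report more compounds than this note shows. Statements on the series, on what has been measured and on what is new or still open speak of the compounds shown alone.

Compound 1 `N#Cc1ccc(Cn2cc(COc3ccc4c(=O)ccoc4c3)nn2)cc1`: in a functional assay on QGY7701 cells (Homo sapiens) for cytotoxicity, read by MTT assay, with a stated time of 48 h (a higher number here means a weaker inhibitor, a lower number a stronger inhibitor), compound 1 gives > 100000 nM, which is a limit of the assay.
Compound 2 `Cc1ccccc1Cn1cc(COc2ccc3c(=O)ccoc3c2)nn1`: in this assay compound 2 gives > 100000 nM, also a limit.
Compound 3 `COc1ccc(Cn2cc(COc3ccc4c(=O)ccoc4c3)nn2)cc1`: in this assay compound 3 gives 56600 nM.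

Compound 2 thus stands at the limit, where two of the three measured values sit (the limit of > 100000 nM in this assay, at which 2 of the 3 values shown sit). Compound 4 `N#Cc1cccc(Cn2cc(COc3ccc4c(=O)ccoc4c3)nn2)c1` differs from compound 2 by 3-cyanophenyl in place of 2-methylphenyl on a saturated chain carbon bound to an aromatic nitrogen. Within the data shown here, two measured steps bear on this change: the step that the two limits leave unreadable from compound 1 to compound 2, which the two limits leave unreadable, and the step of an at least 1.7-fold lower number from compound 2 to compound 3 (0.24 log units; that floor lies within the scatter), whose floor lies within the scatter. Neither shows a benzyl change moving the number beyond the scatter, and compound 1, which also carries a cyano group, sits at the limit. Compound 4 is therefore expected to stay near the limit, with a number no higher from compound 2 to compound 4 (the limit leaves the size open) as the expected step. The estimate for compound 4 is 100000 nM, between 40000 nM and 300000 nM.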

Compound 4, half-maximal inhibitory concentration: 24400 nM
Compound 4: middle estimate off by 4.1-fold (0.61 log units), on the high side; measured number outside the range, below it.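

In this assay, the group on this saturated chain carbon can move the number beyond the scatter, which no earlier readable step had shown, with an at least 4.0-fold lower number from compound 2 to compound 4 (0.61 log units; beyond the scatter). The place of the nitrile matters, as 3-cyanophenyl in place of 4-cyanophenyl gives an at least 4.0-fold lower number from compound 1 to compound 4 (0.61 log units; beyond the scatter), and 3-cyanophenyl in place of 4-methoxyphenyl gives a 2.3-fold lower number from compound 3 to compound 4 (0.37 log units; beyond the scatter). The steps from compound 1 and compound 2 give only floors: the limit of > 100000 nM in this assay, at which 2 of the 4 values shown sit.

From the compounds shown here alone, it remains open whether a 2-cyanophenyl group would behave like 3-cyanophenyl or 4-cyanophenyl. Going by these compounds, the effect of an amine or a carboxylic acid on this ring also remains open.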